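The source may report more compounds than this note shows. Statements on the series, on what has been measured and on what is new or still open speak of the compounds shown alone.

Measured so far:
- Compound 1 `COc1ccc(-c2c3ccc4ccccc4c3nc3c2c(C)nc2c4ccccc4ccc32)cc1`: in a functional assay, read by spectrophotometry, with a stated time of 30 min (on this read-out lower numbers stand for stronger inhibition and higher numbers for weaker inhibition), compound 1 gives 133 ug/mL.
- Compound 2 `Cc1nc2c3ccccc3ccc2c2nc3c(ccc4ccccc43)c(C)c12`: in this assay compound 2 gives 129 ug/mL.

Among the compounds with values here, compound 2 has the lowest of the two numbers in this assay, but its only neighbour is compound 1, and the step of a 1.0-fold lower number from compound 1 to compound 2 (0.01 log units; within the scatter) lies within the scatter, so the two compounds cannot be told apart on these numbers.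

Compound 3 `Cc1nc2c3ccccc3ccc2c2nc3c(ccc4ccccc43)c(-c3ccccc3)c12` has not yet been measured. It differs from compound 2 in one place: phenyl in place of methyl on an aromatic carbon.

Within the data shown here, the only measured step that bears on this change is the one from compound 1 to compound 2, where a 4-methoxyphenyl group was exchanged for a methyl group at the matching position on the other arm of the shared core, and that step a 1.0-fold lower number from compound 1 to compound 2 (0.01 log units; within the scatter) made no difference beyond the scatter. The change from compound 2 to compound 3 runs the other way, from methyl to an aryl group, phenyl here, so the expectation is a step of a 1.0-fold higher number from compound 2 to compound 3 (0.00 log units; within the scatter) in this assay, with no change beyond the scatter.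

Compound 3 is therefore estimated at 130 ug/mL, with a likely range from 65 ug/mL to 260 ug/mL.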

Compound 3, half-maximal inhibitory concentration: 164 ug/mL
The estimate for compound 3 lay 1.3-fold (0.10 log units) below the measured number; measured number inside the range.
By their numbers in this assay, from the lowest: compounds 2, 1 and 3 (each within the scatter of the next).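

In this assay, putting phenyl in place of methyl on this aromatic carbon, opposite the ring nitrogen, gives a 1.3-fold higher number from compound 2 to compound 3 (0.10 log units; within the scatter) and so swaps a single carbon for a whole six-membered aromatic ring without a change that can be told from the scatter. The methoxy group on that aryl ring also makes no readable difference, since hydrogen in its place gives a 1.2-fold higher number from compound 1 to compound 3 (0.09 log units; within the scatter) and leaves compound 1 and compound 3 indistinguishable on these numbers. No measurement shown here offers an explanation for these results.

With every step among these three compounds inside the scatter, nothing yet shows that a change at this position can shift the number in this assay at all. As far as these compounds go, it remains open whether an amine, a carboxylic acid or a longer chain at this position, or on the phenyl ring, would move the number beyond the scatter in either direction.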